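This account rests on a few compounds, and the source may have more. Where it says the series, first, only, none or still open, it means among the compounds named here.

Measured in a functional assay on A549 cells (Homo sapiens) for cytotoxicity, read by resazurin assay, with a stated time of 48 h; a lower number here means a stronger inhibitor, a higher number a weaker inhibitor:
- compound 1 `C=C(C)[C@@H]1CC=C(CN(OC)C2O[C@H](CN=[N+]=[N-])[C@@H](N=[N+]=[N-])[C@H](O)[C@H]2O)CC1`: 44000 nM
- compound 2 `C=C(C)[C@@H]1CC=C(CN(OC)C2O[C@H](CN=[N+]=[N-])[C@@H](O)[C@H](O)[C@H]2O)CC1`: 163000 nM
- compound 3 `C=CCOC(=O)N[C@H]1C(N(CC2=CC[C@@H](C(=C)C)CC2)OC)O[C@H](CO)[C@@H](O)[C@@H]1O`: 114000 nM

Compound 1 has the lowest number of the three, at 44000 nM, and both other values lie beyond the scatter from it. The next compound in the series is compound 4 `C=C(C)[C@@H]1CC=C(CN(OC)C2OC[C@@H](N=[N+]=[N-])[C@H](O)[C@H]2O)CC1`. Its difference from compound 1 is hydrogen in place of azidomethyl on a saturated ring carbon, next to the ring oxygen.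

Among the measured compounds shown here, only one measured step bears on this change. It is a 3.7-fold higher number from compound 1 to compound 2 (0.57 log units; beyond the scatter), with hydroxy in place of azido on a saturated ring carbon. That step removes the other azide-bearing group, at a different place, so it is only a loose guide. For the measured compounds named here, compound 3 offers no matched step. A modest move toward a higher number in this assay is therefore expected, of about the same size as the step to compound 2, though the data do not exclude no change beyond the scatter.

The estimated step is a 2.3-fold higher number from compound 1 to compound 4 (0.36 log units; beyond the scatter). For compound 4 the expected value is 100000 nM, with an estimated range of 45000 nM to 220000 nM.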

Compound 4, half-maximal inhibitory concentration: 76000 nM
Beside the measured number, compound 4's estimate is 1.3-fold (0.12 log units) above it; low and high end bracket the measured number.
By their numbers in this assay, from the lowest: compounds 1, 4, 3 and 2 (each within the scatter of the next, the first and the last beyond it).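

In this assay, hydrogen in place of azidomethyl on a saturated ring carbon, next to the ring oxygen, gives a 1.7-fold higher number from compound 1 to compound 4 (0.24 log units; within the scatter) and so leaves the reading within the scatter. This is the first look at this position, and the azidomethyl group is not shown to be required there for the micromolar reading of compound 1, whereas hydroxy in place of azido at the other site gives a 3.7-fold higher number from compound 1 to compound 2 (0.57 log units; beyond the scatter) as a step beyond the scatter. No available evidence bears on why the replacement behaves this way.

Open, as far as these compounds go, is how hydroxymethyl, aminomethyl or a carboxylic acid would read at this position. Also open, from the compounds shown here alone, is whether hydroxy in place of azido on the core of compound 4 would give a step of similar size to the one seen with azidomethyl present.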